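Configuration and paw edema inhibition in a diester pair

A few compounds are considered here, and "the series" means these few. Any claim that something is new, unique, unknown or untested is made for them only; others in the source may bear on it.

Compound 1 `COc1cc(/C=C/C(=O)/C=C(O)/C=C/c2ccc(OC(=O)[C@H](C)NC(=O)OC(C)(C)C)c(OC)c2)ccc1OC(=O)[C@H](C)NC(=O)OC(C)(C)C` and compound 2 `COc1cc(/C=C/C(=O)/C=C(O)/C=C/c2ccc(OC(=O)[C@@H](C)NC(=O)OC(C)(C)C)c(OC)c2)ccc1OC(=O)[C@@H](C)NC(=O)OC(C)(C)C` share every atom and bond and differ only in how two stereocentres are drawn. In a functional assay on the whole organism (strain Wistar) for inhibition, with Rattus norvegicus as the target, read by paw edema, with stated times of 1 h and 4 h, at a dose of 10 mg/kg by the intraperitoneal route (a lower number here means less inhibition, a higher number more inhibition at the dose given (going by the name of the read-out)), compound 1 gives 28%, while compound 2 gives 42%. Going by the values given here, the step of a number 14 percentage points higher from compound 1 to compound 2 (beyond the scatter) is the only measured change here, and because the fact that compounds 1 and 2 differ only in the configuration as drawn it can be tied to configuration alone. Among the compounds with values here, compound 2 therefore stands highest of the two numbers in this assay, with compound 1 as its only neighbour.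

Compound 3 `COc1cc(/C=C/C(=O)/C=C(O)/C=C/c2ccc(OC(=O)C(C)NC(=O)OC(C)(C)C)c(OC)c2)ccc1OC(=O)C(C)NC(=O)OC(C)(C)C` is the same molecule with neither stereocentre assigned: the two compounds have the same atoms and bonds; at least one stereo element is drawn with a configuration in one of them and without one in the other: 2 of 5 stereo elements differ; a stereocentre at a saturated chain carbon is drawn R in compound 2 and without a configuration in compound 3; a stereocentre at a saturated chain carbon is drawn R in compound 2 and without a configuration in compound 3. The two measured compounds bracket what such undefined material could show, so the step from compound 2 to compound 3 is expected to be a number 7 percentage points lower from compound 2 to compound 3 (within the scatter) in this assay. For compound 3 a value of 35% is expected, within a range of 22% to 48%.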

Compound 3, a percentage reported as inhibition, in the whole organism at one dose (the size of the read-out at that dose, not a potency): 40%
For compound 3 the middle estimate is 5 percentage points below the measured one, and the stated range covers the measured number.
By their numbers in this assay, from the lowest: compound 1; then compounds 3 and 2 (each within the scatter of the next).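

In this assay, the drawing without a stereocentre assignment reads like the R-drawn compound and not like the S-drawn one: the first comparison gives a number 2 percentage points lower from compound 2 to compound 3 (within the scatter), and the second gives a number 12 percentage points higher from compound 1 to compound 3 (beyond the scatter). The defined pair alone showed only that configuration at these two stereocentres can shift the paw edema read-out; compound 3 adds that leaving the configuration unassigned gives a number that cannot be told apart from that of compound 2. Both comparisons involve no change in atoms or bonds: the fact that one of compounds 1 and 3 is drawn with a defined configuration and the other without, at the place where they differ

The drawing of compound 3 does not tell which forms the sample contains, so its number cannot be traced to any particular form. From the compounds shown here alone, whether the R-over-S gap persists with a free amine in place of the tert-butyl carbamate, or with a longer chain at the stereocentre, remains open.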